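The source may report more compounds than this note shows. Statements on the series, on what has been measured and on what is new or still open speak of the compounds shown alone.

Two compounds of this series have been characterised so far. Compound 1 `CCS(=O)(=O)Nc1cc(C2CCCCC2)cc2c1CCCC2c1c[nH]cn1` gives 269 nM in an assay on isolated protein for binding affinity to Alpha-1A adrenergic receptor (Rattus norvegicus), read by radioligand binding; on this read-out higher numbers stand for weaker inhibition and lower numbers for stronger inhibition. Compound 2 `CS(=O)(=O)Nc1ccc(O)c2c1CCCC2c1c[nH]cn1` gives 708 nM in this assay, the higher of the two numbers, with the value of compound 1 standing well below it, further apart than repeated measurements usually scatter. Going by the values given here, compound 2 and compound 1 differ in more than one place, so no single step links them. Compound 3 `CS(=O)(=O)Nc1ccc(F)c2c1CCCC2c1c[nH]cn1` has not yet been measured. It arises from compound 2 by a single change, (fluoro in place of hydroxy on an aromatic carbon). Among the compounds with values here, no step in this assay is available for a change of this kind, and compound 1 offers no guidance on it, so the direction of the step from compound 2 to compound 3 cannot be read from the data. It is expected that the change stays modest, with a 1.4-fold lower number from compound 2 to compound 3 (0.15 log units; within the scatter) not clearly beyond the scatter in either direction. Compound 3 is therefore estimated at 500 nM, within a range from 150 nM to 1700 nM.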

Compound 3, inhibition constant: 309 nM
Compound 3: the middle estimate sits 1.6-fold (0.21 log units) above what was measured; low and high end bracket the measured number.
By their numbers in this assay, from the lowest: compounds 1 and 3 (each within the scatter of the next); then compound 2.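

In this assay, the place para to a methanesulfonamido group proves sensitive to this exchange, with fluoro in place of hydroxy giving a 2.3-fold lower number from compound 2 to compound 3 (0.36 log units; beyond the scatter), a step beyond the usual scatter. The hydroxy group, with its hydrogen-bond donor and acceptor, is therefore not needed at this place for binding in this range, since fluoro, which counts neither, gives the lower number in this one pair. Nothing available bears on the reason for this step.

Going by these compounds, whether a methoxy group, a chlorine atom or an amine at this place would give a number nearer that of compound 2 or compound 3 remains open. So does whether the step would carry over to a core bearing the cyclohexyl group of compound 1.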